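Lengthening the imidazole tether in an inactive series

The source may hold more compounds than are shown below. What is called first, only, known or untested is meant among the compounds shown, and "the series" means these compounds.

Compound 1 `Cn1cc(C2=C(c3nn(CCn4ccnc4)c4ncccc34)C(=O)NC2=O)c2ccccc21`: in a functional assay on ECa-109 cells (Homo sapiens) for antiproliferative activity, read by MTT assay, with a stated time of 48 h (on this read-out lower numbers stand for stronger inhibition and higher numbers for weaker inhibition), compound 1 gives > 100000 nM, a limit of the assay.
Compound 2 `Cn1cc(C2=C(c3nn(CCCN4CCCCC4)c4ncccc34)C(=O)N(c3ccc(Cl)cc3)C2=O)c2ccccc21`: in this assay compound 2 gives > 100000 nM, also a limit of the assay.

Going by the values given here, compound 1 therefore stands at the limit, as does the only other value shown (the limit of > 100000 nM in this assay, at which 2 of the 2 values shown sit). Compound 3 `Cn1cc(C2=C(c3nn(CCCCn4ccnc4)c4ncccc34)C(=O)NC2=O)c2ccccc21` differs from compound 1 in one place.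
2-(1H-imidazol-1-yl)ethyl in place of 1H-imidazol-1-yl on a saturated chain carbon, two bonds along the chain from an aromatic nitrogen
Among the compounds with values here, no step between measured compounds exists, so the data give no guide to the effect of this change. The expected step of a number no higher from compound 1 to compound 3 (the limit leaves the size open) is none beyond the scatter, because both values shown sit at the limit (the limit of > 100000 nM in this assay, at which 2 of the 2 values shown sit). Compound 3 is estimated at 100000 nM, within 30000 nM to 300000 nM, most likely reported again only as a limit.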

Compound 3, half-maximal inhibitory concentration: 23500 nM
The estimate for compound 3 lay 4.3-fold (0.63 log units) above the measured number; measured number outside the range, below it.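

Lengthening the tether, with 2-(1H-imidazol-1-yl)ethyl in place of 1H-imidazol-1-yl on a saturated chain carbon, gives in this assay an at least 4.2-fold lower number from compound 1 to compound 3 (0.62 log units; beyond the scatter). Chain length at this position therefore matters, and compound 3 is the only compound shown that leaves the limit: the limit of > 100000 nM in this assay, at which 2 of the 3 values shown sit. The value for compound 1 is only a limit, so the full size of the step is unknown.

Going by these compounds, whether a still longer chain would lower the number further stays open. So does whether a morpholine or a carboxylic acid at the chain end could replace the imidazole.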